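Replacing acetyl with methylsulfanyl on the shared core

The source may report more compounds than this note shows. Statements on the series, on what has been measured and on what is new or still open speak of the compounds shown alone.

Measured compounds:
compound 1: `NC(=O)c1cccc(-c2cnc(C(=O)CCCCCCc3ccccc3)o2)c1`, 6 nM
compound 2: `NS(=O)(=O)c1ccc(-c2cnc(C(=O)CCCCCCc3ccccc3)o2)s1`, 3 nM
compound 3: `CC(=O)c1cnc(C(=O)CCCCCCc2ccccc2)o1`, 2 nM

All three were run in an assay (Rattus norvegicus) for inhibition of Fatty-acid amide hydrolase 1 (Homo sapiens); a higher number here means a weaker inhibitor, a lower number a stronger inhibitor. Compound 3 has the lowest number of the three; the step of a 3.0-fold lower number from compound 1 to compound 3 (0.48 log units; beyond the scatter) lies beyond the scatter, but the step of a 1.5-fold lower number from compound 2 to compound 3 (0.18 log units; within the scatter) does not, so compound 3 and compound 2 cannot be ranked against each other. The third measured step, a 2.0-fold lower number from compound 1 to compound 2 (0.30 log units; within the scatter), is also within the scatter. Taken together, three quite different groups at this position of the shared core give numbers within a narrow band.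

The next compound, compound 4 `CSc1cnc(C(=O)CCCCCCc2ccccc2)o1`, changes compound 3 by methylsulfanyl in place of acetyl on an aromatic carbon. Going by the values given here, no measured step replaces the acetyl itself, so the change has no direct precedent. Among the compounds with values here, what the series does show is that swapping the group at this position, even between groups as different as 3-carbamoylphenyl and acetyl, moved the number by no more than the step of a 3.0-fold lower number from compound 1 to compound 3 (0.48 log units; beyond the scatter). The expected step of a 2.0-fold higher number from compound 3 to compound 4 (0.30 log units; within the scatter) is therefore small, at most a modest rise in the number, and likely within the scatter. Compound 4 is expected to give about 4 nM, with a range from 1.5 nM to 12 nM.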

Compound 4, inhibition constant: 25 nM
Estimate against measurement, compound 4: 6.3-fold (0.80 log units) below, and the stated range ends below it.
By their numbers in this assay, from the lowest: compounds 3, 2 and 1 (each within the scatter of the next, the first and the last beyond it); then compound 4.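

In this assay, going by these compounds alone, this position, on an aromatic carbon next to the ring oxygen, proves less forgiving than the earlier compounds suggested: a 13-fold higher number from compound 3 to compound 4 (1.10 log units; beyond the scatter) is larger than any step among compounds 1, 2 and 3. Compound 4 also stands apart from the two aryl-bearing compounds, with an 8.3-fold higher number from compound 2 to compound 4 (0.92 log units; beyond the scatter) and a 4.2-fold higher number from compound 1 to compound 4 (0.62 log units; beyond the scatter), so the narrow band holds for acetyl, 5-sulfamoylthiophen-2-yl and 3-carbamoylphenyl, while methylsulfanyl falls outside it. The size of the group does not set the order on its own here, as methylsulfanyl differs from acetyl by a single heavy atom, and no measurement available explains the rise.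

The compounds shown leave open whether the rise goes with the sulfur or with the loss of the carbonyl, a question that a methoxy, methylsulfonyl or plain methyl group at this position would help to separate. Also open, on these data alone, is whether a longer thioether such as ethylsulfanyl would follow methylsulfanyl or return to the band of the other three groups.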